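Substituent at the saturated ring carbon: compound 3 to compound 4

The source may hold more compounds than are shown below. What is called first, only, known or untested is meant among the compounds shown, and "the series" means these compounds.

Measured so far in a functional assay on HEK293 cells for agonist activity at G-protein coupled receptor 39 (Homo sapiens), read by scintillation proximity assay and inositol phosphate accumulation, with a stated time of 75 min; a lower number here means that less compound is needed, a higher number that more compound is needed for the effect:
compound 1 `Cc1nn(-c2ncnc3nc[nH]c23)c2c1C(OCc1ccc(Cl)cc1Cl)CC(=O)N2` gives 243 nM
compound 2 `Cc1cc(C)nc(-n2nc(C)c3c2NC(=O)CC3c2ccc(COc3cccc(Cl)c3)cc2)n1` gives 3000 nM
compound 3 `Cc1nn(-c2ncnc3nc[nH]c23)c2c1C(c1ccc(OC(C)C)cc1)CC(=O)N2` gives 2700 nM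

Compound 3 stands second highest of the three numbers. Its nearest neighbour is compound 2, whose value lies within the scatter of that of compound 3; the furthest is compound 1, which is beyond the scatter lower.

The step under consideration leads to compound 4 `Cc1nn(-c2ncnc3nc[nH]c23)c2c1C(C(=O)N(C)c1ccccc1)CC(=O)N2`, not yet measured in this assay. The change is methyl(phenyl)carbamoyl in place of 4-isopropoxyphenyl on a saturated ring carbon. The substituent leaving and the one entering have the same count of heavy atoms and each carries one six-membered aromatic ring of carbon only and one hydrogen-bond acceptor, but the entering group adds a double bond outside aromatic rings and a nitrogen.

Among the compounds with values here, only one measured step touches the same place: an 11-fold higher number from compound 1 to compound 3 (1.05 log units; beyond the scatter). It shows that the group on this saturated ring carbon moves the number strongly, yet nothing measured pairs an aryl group directly with a carbamoyl group there, so the direction of the step to compound 4 is not fixed by the data.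

Compound 4 is therefore expected at 2000 nM, within 400 nM to 10000 nM. The estimated step of a 1.4-fold lower number from compound 3 to compound 4 (0.13 log units; within the scatter) is small in the middle but wide in range.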

Compound 4, half-maximal effective concentration: 5220 nM
Estimate against measurement, compound 4: 2.6-fold (0.42 log units) below; the range from low to high includes it.
By their numbers in this assay, from the lowest: compound 1; then compounds 3, 2 and 4 (each within the scatter of the next).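

In this assay, the change from 4-isopropoxyphenyl to methyl(phenyl)carbamoyl on the saturated ring carbon gives a 1.9-fold higher number from compound 3 to compound 4 (0.29 log units; within the scatter). Two groups with the same count of heavy atoms, each with a six-membered aromatic ring of carbon only, are therefore not separated here, even though the entering group adds a nitrogen and a double bond outside aromatic rings. The second step, a 21-fold higher number from compound 1 to compound 4 (1.33 log units; beyond the scatter), shows that a carbamoyl group, like the 4-isopropoxyphenyl group, stands far from (2,4-dichlorobenzyl)oxy, which leaves compound 1 alone at the low end among the three compounds that share this core, and no independent data bear on the reason for these numbers.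

The (2,4-dichlorobenzyl)oxy group differs from both other groups in more than one feature, so the compounds shown cannot say whether the low number of compound 1 goes with the ether oxygen, the benzyl chain or the two chlorines. An unsubstituted benzyloxy group, a 2,4-dichlorophenyl group or a carbamoyl group that keeps the amide hydrogen at this carbon would bear on these questions.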